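Two quinoline acrylic acids and a pyrazole analogue in lipophilicity

The source may hold more compounds than are shown below. What is called first, only, known or untested is meant among the compounds shown, and "the series" means these compounds.

Measured so far:
compound 1, `C[C@H](Oc1ccc2ncc(/C=C/C(=O)O)c(C3CC3)c2c1)c1c(Cl)ccnc1Cl`, 2.3
compound 2, `C[C@H](Oc1ccc2ncc(/C=C/C(=O)O)c(O)c2c1)c1c(Cl)ccc(F)c1Cl`, 1.9

In a physicochemical assay for lipophilicity, using the shake flask method (a higher number here means a more lipophilic compound, a lower number a more polar compound), compound 1 gives 2.3, the higher of the two numbers; compound 2, which carries a different side group and a hydroxyl on the shared core, gives 1.9, a value lower than that of compound 1 by an amount beyond the scatter. Going by the values given here, no pair of compounds differing in a single place has been measured, so there is no directly comparable step to lean on.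

Compound 3, `Cc1cnn(C)c1[C@H](C)Oc1ccc2ncc(/C=C/C(=O)O)c(C3CC3)c2c1`, differs from compound 1 in one place: 1,4-dimethyl-1H-pyrazol-5-yl in place of 2,4-dichloropyridin-3-yl on a saturated chain carbon bound to an oxygen on an aromatic ring and a saturated chain carbon. The whole rest of the molecule, including the acrylic acid and the cyclopropyl on the shared core, is kept.

Among the compounds with values here, with no single-change step on record, the expectation rests on the change itself and on the spread between compound 1 and compound 2. Compound 3 is expected to fall below compound 1 by a step of a number 1.20 log units lower from compound 1 to compound 3 (beyond the scatter), clearly beyond the scatter. The estimate for compound 3 in this assay is 1.1, with a likely range from 0.5 to 1.7.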

Compound 3, distribution coefficient: 0.9
Compound 3: middle estimate off by 0.20 log units, on the high side, and the stated range covers the measured number.
By their numbers in this assay, from the lowest: compound 3; then compound 2; then compound 1.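

In this assay, going by these compounds alone, putting 1,4-dimethyl-1H-pyrazol-5-yl in place of 2,4-dichloropyridin-3-yl on a saturated chain carbon bound to an oxygen on an aromatic ring and a saturated chain carbon gives a number 1.40 log units lower from compound 1 to compound 3 (beyond the scatter), a large step and the only single-change step on record in this set. The gap between compound 1 and compound 2 could not be tied to one place, as those two differ in more than one, whereas here the acrylic acid, the cyclopropyl and the rest of the molecule are kept, so this position alone is shown to move the number by this much. No measurement at hand says what lies behind the size of this step.

The compounds shown leave open which part of the exchange carries the step, as the two chlorines, the ring size, the hetero atoms and the two methyl groups all change together in it. They also leave open where a 2,4-dimethylpyridin-3-yl group, which keeps the six-membered ring but carries methyl groups in place of chlorine, would fall at this position.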